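A few compounds are considered here, and "the series" means these few. Any claim that something is new, unique, unknown or untested is made for them only; others in the source may bear on it.

Measured to date in an assay on isolated protein for inhibition of Ca2+/calmodulin-dependent protein kinase II (CaM kinase II) (Rattus norvegicus), tested at 30 uM; on this read-out lower numbers stand for less inhibition and higher numbers for more inhibition at the one concentration tested (going by the name of the read-out):

compound 1 `c1ccc(-[n+]2c[nH]c3ncncc32)cc1` — 0%
compound 2 `Clc1ncnc2c1ncn2Cc1ccccc1` — 7%
compound 3 `Fc1ccc(Cn2cnc3c(Cl)ncnc32)cc1` — 0%

For the measured compounds named here, compound 3 stands level with compound 1 at the digits given, the two together the lowest of the three numbers; compound 2 sits a little higher, but the only single-point step in the set, a number 7 percentage points lower from compound 2 to compound 3 (within the scatter), lies within the scatter of this assay, so all three numbers sit at the low end of the read-out at the concentration tested.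

Compound 4 `Nc1ncnc2c1ncn2Cc1ccc(F)cc1` is the next member. It differs from compound 3 by amino in place of chloro on an aromatic carbon. Going by the values given here, no measured step concerns an exchange of chloro for amino; the one step available, fluoro for hydrogen on an aromatic carbon, was within the scatter. With the whole set at the floor of the read-out and nothing to suggest that this change behaves differently, no step beyond the scatter is expected. Compound 4 is therefore estimated at 3% in this assay, with a range of 0% to 15%, which corresponds to an expected step of a number 3 percentage points higher from compound 3 to compound 4 (within the scatter).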

Compound 4, a percentage reported as inhibition, at one concentration (the size of the read-out at that concentration, not a potency): 9%
Beside the measured number, compound 4's estimate is 6 percentage points below it; the measured number falls inside the stated range.
By their numbers in this assay, from the lowest: compounds 1, 3, 2 and 4 (each within the scatter of the next).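

In this assay, the exchange of chloro for amino on an aromatic carbon of the six-membered aromatic ring with 2 nitrogen gives a number 9 percentage points higher from compound 3 to compound 4 (within the scatter). For the compounds shown here, this is the first reading at this position, as the earlier step, fluoro in place of hydrogen, concerned a different aromatic carbon; here, entry of an amino group with 1 hydrogen-bond donor and 1 hydrogen-bond acceptor leaves the change within the scatter. Nothing at hand bears on the reason for this result.

Open, going by these compounds, is whether a methoxy group, a dimethylamino group or a longer amine chain at this position would give a step beyond the scatter. Also open, on these data alone, is whether fluoro in place of hydrogen would give a comparable step with amino on the shared core.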